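Hydroxycyclohexyl for Hydroxypropyl: Expected Microsomal Half-Life

The compounds below may be only part of what the source reports. "The series", "measured", "known", "first", "only" and "open" are said of these compounds alone.

Compound 1, `N=c1c2c(-c3ccccc3)c(-c3ccccc3)n(Cc3ccccc3)c2ncn1CCNc1ccncc1`, gives 0.498 h in an ADME assay on microsomes from liver (Mus musculus, strain CD1) for metabolic stability, read by LC-MS, using NADPH, with a stated time of 60 min; on this read-out lower numbers stand for a shorter-lived compound and higher numbers for a longer-lived compound.
Compound 2, `COc1ccc(-c2c(-c3ccc(OC)cc3)n(Cc3ccccc3)c3ncn(CCCO)c(=N)c23)cc1`, gives 0.36 h in this assay.
Compound 3, `COc1ccc(Cn2c(-c3ccccc3)c(-c3ccccc3)c3c(=N)n(CC4CCCO4)cnc32)cc1`, gives 0.157 h in this assay.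

Of these three numbers, compound 2 holds the second highest, but its gap to compound 1 is within the usual scatter, so the two cannot be ordered; compound 3 lies lower, beyond the scatter. The unmeasured compound 4, `COc1ccc(-c2c(-c3ccc(OC)cc3)n(Cc3ccccc3)c3ncn([C@@H]4CCCC[C@H]4O)c(=N)c23)cc1`, differs from compound 2 by 2-hydroxycyclohexyl in place of 3-hydroxypropyl on an aromatic nitrogen. Among the measured compounds shown here, no measured pair shows this change, so no step size is known from the data. The change is expected to move the number little, if at all beyond the scatter. Compound 4 is expected to give about 0.4 h, with a range from 0.15 h to 1 h. The estimated step is a 1.1-fold higher number from compound 2 to compound 4 (0.05 log units; within the scatter).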

Compound 4, half-life: 0.487 h
For compound 4 the middle estimate is 1.2-fold (0.09 log units) below the measured one, and the stated range covers the measured number.
By their numbers in this assay, from the lowest: compound 3; then compounds 2, 4 and 1 (each within the scatter of the next).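

Placing 2-hydroxycyclohexyl in place of 3-hydroxypropyl on the aromatic nitrogen gives a 1.4-fold higher number from compound 2 to compound 4 (0.13 log units; within the scatter) in this assay. On the core shared by these two compounds, the open-chain and the ring-bearing hydroxy groups therefore cannot be told apart by half-life at this position. Nothing available explains this result. The compounds shown leave open whether 2-hydroxycyclohexyl with its stereocentres reversed would read the same, and how a carboxylic acid or a longer chain on this nitrogen would read.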